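The compounds below may be only part of what the source reports. "The series", "measured", "known", "first", "only" and "open" are said of these compounds alone.

Compound 1 `O=C1/C(=C/c2ccccc2)CCC/C1=C\c1cccc([N+](=O)[O-])c1` gives 5.06 in a physicochemical assay for lipophilicity; a higher number here means a more lipophilic compound, a lower number a more polar compound. Compound 2 `O=C1/C(=C/c2ccc(F)cc2)CCC/C1=C\c1cccc([N+](=O)[O-])c1`, which carries fluoro in place of hydrogen on an aromatic carbon, gives 5.06 in this assay, so that the step of no change at the digits printed from compound 1 to compound 2 (within the scatter) leaves it level with compound 1 at the digits shown, within the scatter. Compound 3 `O=C1/C(=C/c2ccc(Cl)cc2)CCC/C1=C\c1cccc([N+](=O)[O-])c1` has not yet been measured; it differs from compound 2 by chloro in place of fluoro on an aromatic carbon. Among the measured compounds shown here, the only measured step, from compound 1 to compound 2, touched the same aromatic carbon but swapped hydrogen for fluoro and brought no change beyond the scatter; no measured pair shows fluoro against chloro. Compound 3 is therefore expected to run somewhat higher than compound 2 in this assay, by a step of a number 0.44 log units higher from compound 2 to compound 3 (beyond the scatter), likely beyond the scatter but not large. The value estimated for compound 3 is 5.5, within a range from 5.1 to 5.9.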

Compound 3, partition coefficient: 5.06
Compound 3: the middle estimate sits 0.44 log units above what was measured, and the stated range ends above it.
By their numbers in this assay, from the lowest: compounds 1, 2 and 3 (each within the scatter of the next).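

In this assay, the change from 4-fluorophenyl to 4-chlorophenyl brings no change at the digits printed from compound 2 to compound 3 (within the scatter), and chloro in place of hydrogen on this aromatic carbon, para to a large group, brings no change at the digits printed from compound 1 to compound 3 (within the scatter). The earlier pair spoke only for fluoro against hydrogen; now hydrogen, fluoro and chloro all read alike at this position on the shared core. Across these three compounds, then, this assay does not separate the two halogens from each other or from hydrogen.

As far as these compounds go, whether an amine, a methoxy group or a carboxylic acid at this position would give a step beyond the scatter stays open, as does the effect of changing the nitro group, which all three compounds share. The data shown offer no evidence that would explain the level reading.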